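From compound 2 to its 4-fluorophenyl analogue

The compounds below may be only part of what the source reports. "The series", "measured", "known", "first", "only" and "open" are said of these compounds alone.

In a functional assay on COR-L23 cells (Homo sapiens) for antiproliferative activity, read by CellTiter-Glo, with a stated time of 4 days (on this read-out higher numbers stand for weaker inhibition and lower numbers for stronger inhibition), compound 1 `C[C@H](NC(=O)CC(F)(F)F)c1ccc(NC(=O)[C@H]2C[C@@H]2c2cccnc2)cc1` gives 18 nM and compound 2 `C[C@H](NC(=O)c1ccccc1)c1ccc(NC(=O)[C@H]2C[C@@H]2c2cccnc2)cc1` gives 8 nM, the lower of the two numbers. Among the compounds with values here, the only measured step, a phenyl in place of 2,2,2-trifluoroethyl on a carbonyl carbon, is a 2.3-fold lower number from compound 1 to compound 2 (0.35 log units; beyond the scatter), a modest change for the exchange of a whole group. Compound 3 `C[C@H](NC(=O)c1ccc(F)cc1)c1ccc(NC(=O)[C@H]2C[C@@H]2c2cccnc2)cc1` has fluoro in place of hydrogen on an aromatic carbon of that phenyl: fluoro in place of hydrogen on an aromatic carbon. Within the data shown here, no measured step tests this smaller change, so nothing beyond the scatter is expected. The expected step is no change at the digits printed from compound 2 to compound 3 (within the scatter). Compound 3 is estimated at 8 nM, with an expected range of 4 nM to 16 nM.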

Compound 3, half-maximal inhibitory concentration: 12 nM
Estimate against measurement, compound 3: 1.5-fold (0.18 log units) below; measured number inside the range.
By their numbers in this assay, from the lowest: compounds 2, 3 and 1 (each within the scatter of the next, the first and the last beyond it).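

Fluoro in place of hydrogen on the phenyl, para to a large group, is accommodated at this position: the step (a 1.5-fold higher number from compound 2 to compound 3 (0.18 log units; within the scatter)) cannot be told from repeat measurement. Compound 3 is also not separated from the 2,2,2-trifluoroethyl amide (a 1.5-fold lower number from compound 1 to compound 3 (0.18 log units; within the scatter)), although compound 1 and compound 2 are separated, so the fluoro leaves compound 3 within the scatter of both. Nothing available here gives a reason for this result.

Open, from the compounds shown here alone, is whether a larger group at this position, such as chloro, methoxy or an amine, would be accommodated as well.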